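This account rests on a few compounds, and the source may have more. Where it says the series, first, only, none or still open, it means among the compounds named here.

Measured in a functional assay on HL-60 cells (Homo sapiens) for inhibition, read by MTT assay, with a stated time of 72 h (on this read-out lower numbers stand for stronger inhibition and higher numbers for weaker inhibition), so far:
- compound 1 `Cc1nc(-c2ccccc2)c(C(=O)N2CCN(c3cccc(Cl)c3)CC2)o1` gives 39.2 nM here
- compound 2 `Cc1nc(-c2ccccc2)c(C(=O)N2CCN(c3cccc(Cl)c3Cl)CC2)o1` gives 133 nM here
- compound 3 `Cc1nc(-c2ccccc2)c(C(=O)N2CCN(c3ccc(F)cc3)CC2)o1` gives > 1000 nM here, which is a limit and not a number

Compound 3 therefore stands at a limit, with no exact value of its own. Compound 4 `CC(=O)Nc1cccc(N2CCN(C(=O)c3oc(C)nc3-c3ccccc3)CC2)c1` changes one group of compound 3 (3-acetamidophenyl in place of 4-fluorophenyl on an amine nitrogen in a ring), with 3-acetamidophenyl in place of 4-fluorophenyl on an amine nitrogen in a ring. Two measured changes bear on this: an at least 25-fold higher number from compound 1 to compound 3 (1.40 log units; beyond the scatter) and an at least 7.5-fold higher number from compound 2 to compound 3 (0.87 log units; beyond the scatter) for the two chlorinated groups giving way to 4-fluorophenyl. Both were losses, and 3-acetamidophenyl moves away from 4-fluorophenyl, so some recovery seems likely. Going by the values given here, no measured compound carries the acetamido group, however, so the recovery should be partial and is uncertain. The expected change is an at least 3.3-fold lower number from compound 3 to compound 4 (0.52 log units; beyond the scatter) toward stronger inhibition. Compound 4 is estimated at 300 nM with an expected range from 60 nM to 1500 nM in this measurement.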

Compound 4, half-maximal inhibitory concentration: 329 nM
Compound 4: the middle estimate sits 1.1-fold (0.04 log units) below what was measured, and the stated range covers the measured number.
By their numbers in this assay, from the lowest: compound 1; then compound 2; then compound 4. At a limit, above all of these: compound 3.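

Replacing 4-fluorophenyl with 3-acetamidophenyl at this place gives a clear gain: an at least 3.0-fold lower number from compound 3 to compound 4 (0.48 log units; beyond the scatter). Compound 3 gives only a limit, > 1000 nM, so that step has a minimum size and no exact one. The acetamido group, with its hydrogen-bond donor and acceptor, is tolerated here but does not match either chlorinated group: an 8.4-fold higher number from compound 1 to compound 4 (0.92 log units; beyond the scatter), and a 2.5-fold higher number from compound 2 to compound 4 (0.39 log units; beyond the scatter).

Compound 3 and compound 4 differ in both the group and its ring position, so the compounds shown cannot separate these two changes. From the compounds shown here alone, how an amine or a carboxylic acid would compare at this place stays open.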